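Aryl swap on the pyrazole carboxylic acid core: compound 3

A few compounds are considered here, and "the series" means these few. Any claim that something is new, unique, unknown or untested is made for them only; others in the source may bear on it.

Measured compounds:
Compound 1 `Cc1ccc(-c2c(C)nn(-c3nc(-c4ccc(Cl)c(Cl)c4)c(SC(C)C)s3)c2C(=O)O)cc1`: 3800 nM
Compound 2 `Cc1nn(-c2nc(-c3ccc(Cl)c(Cl)c3)c(SC(C)C)s2)c(C(=O)O)c1-c1cnn(C)c1`: 6800 nM

In a functional assay on BJAB cells (Homo sapiens) for antiproliferative activity, with a stated time of 4 days (on this read-out higher numbers stand for an effect only at larger amounts of compound and lower numbers for an effect already at smaller amounts), compound 1 gives 3800 nM and compound 2 gives 6800 nM. Compound 2 holds the highest of the two numbers, but its neighbour is compound 1, and the step of a 1.8-fold higher number from compound 1 to compound 2 (0.25 log units; within the scatter) falls within the scatter, so the two values cannot be ordered.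

Compound 3 `Cc1nn(-c2nc(-c3ccc(Cl)c(Cl)c3)c(SC(C)C)s2)c(C(=O)O)c1-c1cncc(C#N)c1` carries the change (5-cyanopyridin-3-yl in place of 1-methyl-1H-pyrazol-4-yl on an aromatic carbon). For the measured compounds named here, the only measured step that bears on this position is a 1.8-fold higher number from compound 1 to compound 2 (0.25 log units; within the scatter), which exchanged one aryl group for another at the same ring carbon and stayed within the scatter. That single step gives no ground to expect a movement in this assay beyond the scatter for a further aryl exchange here.

For compound 3 the expected value in this assay is therefore 5000 nM, with a range from 2000 nM to 14000 nM. The step this estimate implies, a 1.4-fold lower number from compound 2 to compound 3 (0.13 log units; within the scatter), is expected to stay within the scatter.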

Compound 3, half-maximal effective concentration: 20000 nM
Estimate against measurement, compound 3: 4.0-fold (0.60 log units) below; the measured number lies above the stated range.
By their numbers in this assay, from the lowest: compounds 1 and 2 (each within the scatter of the next); then compound 3.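

In this assay, for the compounds shown here, the aromatic carbon bearing the aryl group turns out not to be indifferent to what sits there: 5-cyanopyridin-3-yl in place of 1-methyl-1H-pyrazol-4-yl gives a 2.9-fold higher number from compound 2 to compound 3 (0.47 log units; beyond the scatter) and is the first exchange at this place to pass beyond the scatter. Against 4-methylphenyl, the same group gives a 5.3-fold higher number from compound 1 to compound 3 (0.72 log units; beyond the scatter) and so sets compound 3 apart from both earlier compounds, while ring size alone does not sort the series, since compound 1, with its six-membered ring, stays within the scatter of compound 2, with its five-membered ring. No accompanying measurement speaks to what lies behind this loss of activity.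

The compounds shown leave open whether the step goes with the nitrile or with the ring nitrogen of the pyridine, since 5-cyanopyridin-3-yl brings both at once, and a plain pyridinyl group or a cyanophenyl group would separate the two. On these data alone, it also remains open how this carbon would respond to a group that is not an aromatic ring at all, such as an amine or a short alkyl chain.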